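Quinolinone Esters and a Nitrile: Weak Cytotoxicity Throughout

The compounds below may be only part of what the source reports. "The series", "measured", "known", "first", "only" and "open" are said of these compounds alone.

Measured so far:
compound 1, `CCOC(=O)Cn1c(=O)c(-c2ccc(OC)cc2)cc2c(OC)cc(OC)cc21`, 10000 nM
compound 2, `COc1ccc(-c2cc3c(OC)cc(OC)cc3n(CC(=O)OCc3ccccc3)c2=O)cc1`, 10000 nM

In a functional assay on U-373MG ATCC cells for cytotoxicity against U373 MG (Homo sapiens), read by colorimetric assay and MTT assay (on this read-out higher numbers stand for weaker inhibition and lower numbers for stronger inhibition), compound 1 gives 10000 nM. In this assay compound 2 gives 10000 nM, so compound 2 stands level with compound 1 at the digits shown. For the measured compounds named here, the one measured step, no change at the digits printed from compound 1 to compound 2 (within the scatter), was a change of phenyl in place of methyl on a saturated chain carbon bound to an oxygen next to a carbonyl group, and it left the read-out unmoved.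

Compound 3, `COc1ccc(-c2cc3c(OC)cc(OC)cc3n(CCC#N)c2=O)cc1`, has not yet been tested in this assay. It differs from compound 2 by cyanomethyl in place of benzyloxycarbonyl on a saturated chain carbon bound to an aromatic nitrogen. Going by the values given here, no measured step alters this part of the molecule in the same way; the only step on record, no change at the digits printed from compound 1 to compound 2 (within the scatter), varied the ester and produced nothing beyond the scatter. The record therefore gives no ground for expecting movement, and compound 3 is estimated to stay near compound 2, an expected step of no change at the digits printed from compound 2 to compound 3 (within the scatter). Compound 3 is expected to give about 10000 nM in this assay, with a range of 4000 nM to 25000 nM.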

Compound 3, half-maximal inhibitory concentration: 10000 nM
Compound 3: middle estimate and measured number agree at the digits printed, and the stated range covers the measured number.
By their numbers in this assay, from the lowest: compounds 1, 2 and 3 (each within the scatter of the next).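

Until this point only the alcohol part of the ester had changed, whereas here the ester itself gives way: in this assay, cyanomethyl in place of benzyloxycarbonyl on a saturated chain carbon bound to an aromatic nitrogen gives no change at the digits printed from compound 2 to compound 3 (within the scatter), and the same exchange for ethoxycarbonyl gives no change at the digits printed from compound 1 to compound 3 (within the scatter). Among these three compounds, then, the read-out at this place does not depend on an ester being present, and replacing a group of 10 heavy atoms carrying an aromatic ring with one of 3 heavy atoms and no ring produces no step beyond the scatter. No measured evidence accompanies these compounds to say why the read-out stays the same.

As far as these compounds go, what remains open is whether any group at this place can move the read-out at all, as an amine or a carboxylic acid in place of the nitrile, or a longer chain, might show. Also open, from the compounds shown here alone, is whether changing the methoxy groups on the shared core would alter the result, as all three compounds carry them unchanged.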